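Cyclopentylsulfanyl for isobutylsulfanyl in a cytotoxicity screen

A few compounds are considered here, and "the series" means these few. Any claim that something is new, unique, unknown or untested is made for them only; others in the source may bear on it.

Measured compounds:
compound 1 `CC(C)CSc1nc(N)nc2c1ncn2/C=C1/CC1(CO)CO` gives 60000 nM in an ADME assay on CCRF-HSB-2 cells (Homo sapiens) for cytotoxicity, with a stated time of 7 days; a lower number here means that less compound is tolerated, a higher number that more compound is tolerated;
compound 2 `CCCCCCCCOc1nc(N)nc2c1ncn2/C=C1/CC1(CO)CO` gives > 20000 nM in this assay, which is a limit of the assay;
compound 3 `CCCNc1nc(N)nc2c1ncn2/C=C1/CC1(CO)CO` gives > 20000 nM in this assay, also a limit.

For the measured compounds named here, compound 1 holds the only number in the set; the two other values are limits, as the limit of > 20000 nM in this assay, at which 2 of the 3 values shown sit, records. The steps a step that the limit leaves unreadable from compound 1 to compound 2 and a step that the limit leaves unreadable from compound 1 to compound 3 are therefore unreadable, and so is a step that the two limits leave unreadable from compound 2 to compound 3. Compound 4 `Nc1nc(SC2CCCC2)c2ncn(/C=C3/CC3(CO)CO)c2n1` differs from compound 1 only by cyclopentyl in place of isobutyl on a sulfur. Going by the values given here, no measured step bears on this change, so no shift beyond the usual scatter of this assay is expected. The estimate for compound 4 is 60000 nM, between 20000 nM and 150000 nM. This expectation amounts to a step of no change at the digits printed from compound 1 to compound 4 (within the scatter).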

Compound 4, half-maximal cytotoxic concentration: 91000 nM
Compound 4: middle estimate off by 1.5-fold (0.18 log units), on the low side; the range from low to high includes it.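

In this assay, for the compounds shown here, cyclopentyl on the sulfur in place of isobutyl gives a 1.5-fold higher number from compound 1 to compound 4 (0.18 log units; within the scatter), the only step in the set that can be read. A five-membered ring can therefore stand in place of the open isobutyl group on this sulfur, and the two compounds cannot be told apart in this assay. The steps to compound 2 and compound 3 cannot be read: the limit of > 20000 nM in this assay, at which 2 of the 4 values shown sit.

On these data alone, whether a benzyl group or a chain ending in an amine on the same sulfur would also leave the value within the scatter remains open.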